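The source may report more compounds than this note shows. Statements on the series, on what has been measured and on what is new or still open speak of the compounds shown alone.

Compound 3, `COc1ccc(N(C(=O)CN2C=CN(c3ccccc3)C(=O)C(Cc3n[nH]c4cc(F)ccc34)C2=O)C(C)C)cc1`, stands lowest among the three measured compounds in a functional assay on CHO cells for agonist activity at Melanocyte-stimulating hormone receptor (Homo sapiens), read by a luciferase reporter, with a stated time of 4 h (a higher number here means that more compound is needed for the effect, a lower number that less compound is needed), where compound 3 gives 1.59 nM. The nearest measured compound is compound 1, `CC(C)N(C(=O)CN1C=CN(c2ccccc2)C(=O)[C@H](Cc2n[nH]c3cc(F)ccc23)C1=O)c1ccccc1`, which in this assay gives 35.5 nM; the furthest is compound 2, `CC(C)N(C(=O)CN1C=CN(c2ccccc2)C(=O)C(Cc2n[nH]c3ccccc23)C1=O)c1ccccc1`, which gives 708 nM. Both of these gaps lie beyond the usual scatter.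

Compound 4, `CC(C)N(C(=O)CN1C=CN(c2ccccc2)C(=O)C(Cc2n[nH]c3cc(F)ccc23)C1=O)c1ccccc1`, differs from compound 3 in one place: hydrogen in place of methoxy on an aromatic carbon, so that the isopropyl(4-methoxyphenyl)amino group becomes isopropyl(phenyl)amino. Going by the values given here, no pair of measured compounds shows this change alone, so its size can only be guessed from what compounds 1 and 2 show, which both carry the plain phenyl and sit well above compound 3. On that basis compound 4 is expected to need more compound than compound 3, with an expected step of a 38-fold higher number from compound 3 to compound 4 (1.58 log units; beyond the scatter) in this assay, beyond the scatter. Compound 4 is therefore estimated at 60 nM, in a range from 20 nM to 200 nM.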

Compound 4, half-maximal effective concentration: 186 nM
Estimate against measurement, compound 4: 3.1-fold (0.49 log units) below; the measured number falls inside the stated range.
By their numbers in this assay, from the lowest: compound 3; then compound 1; then compound 4; then compound 2.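

In this assay, the 4-methoxyphenyl group turns out to carry a large weight of its own: replacing it with phenyl gives a 120-fold higher number from compound 3 to compound 4 (2.07 log units; beyond the scatter). Fluoro in place of hydrogen on the shared core is a much smaller step, a 3.8-fold lower number from compound 2 to compound 4 (0.58 log units; beyond the scatter), so on these compounds the methoxy change outweighs the fluoro change. The step of a 5.2-fold higher number from compound 1 to compound 4 (0.72 log units; beyond the scatter) involves no change of atoms or bonds, and the only difference behind it is this: the fact that one of compounds 1 and 4 is drawn with a defined configuration and the other without, at the place where they differ

Whether another group could stand in for methoxy on that aromatic carbon stays open, as no ethoxy, hydroxy or chloro group appears there among the compounds shown. From the compounds shown here alone, compound 3 is itself drawn without a configuration, so what a single defined form of it would give also remains open.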